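Cyano to Fluoro on the Benzyl Sulfonamide

A few compounds are considered here, and "the series" means these few. Any claim that something is new, unique, unknown or untested is made for them only; others in the source may bear on it.

Within the data shown here, compound 1 `N#Cc1ccc(CS(=O)(=O)NC(=O)C2CCN(c3nc4c(cc3C#N)C(=O)OC4)CC2)cc1` is the only compound here with a number: in a functional assay (Platelet, plasma) for inhibition, with Homo sapiens as the target (a higher number here means a weaker inhibitor, a lower number a stronger inhibitor), compound 1 gives 8900 nM. Compound 2 `N#Cc1cc2c(nc1N1CCC(C(=O)NS(=O)(=O)Cc3ccccc3)CC1)CCOC2=O` reaches only a limit of the assay, > 300000 nM, in this assay; that sits at the limit of > 300000 nM in this assay, at which 1 of the 2 values shown sits. Compound 3 `N#Cc1cc2c(nc1N1CCC(C(=O)NS(=O)(=O)Cc3ccc(F)cc3)CC1)COC2=O` differs from compound 1 by fluoro in place of cyano on an aromatic carbon. Among the measured compounds shown here, with no measured step for that change, a small shift is expected in this assay, if any beyond the scatter, leaning weaker. Compound 3 is estimated at 15000 nM, between 4000 nM and 60000 nM, a step of a 1.7-fold higher number from compound 1 to compound 3 (0.23 log units; within the scatter).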

Compound 3, half-maximal inhibitory concentration: 3500 nM
Beside the measured number, compound 3's estimate is 4.3-fold (0.63 log units) above it; measured number outside the range, below it.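

Fluoro in place of cyano on this aromatic carbon, para to a large group, gives a 2.5-fold lower number from compound 1 to compound 3 (0.41 log units; beyond the scatter) in this assay. Among these compounds, this is the first reading at this position: the number responds to the change beyond the scatter, and the cyano group is not needed for the activity of compound 3. No measurement shown accounts for the step.

From the compounds shown here alone, whether an amine, a carboxylic acid or a methoxy group at this position would lower the number further remains open. So does whether fluoro gives a similar step on a different core.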